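This account rests on a few compounds, and the source may have more. Where it says the series, first, only, none or still open, it means among the compounds named here.

Measured so far in a functional assay on A549 cells (Homo sapiens) for cytotoxicity; a higher number here means that more compound is needed for the effect, a lower number that less compound is needed:
- compound 1 `COC1=C(C)C(=O)/C(=C(O)/C=C/c2ccc(Br)cc2)C(=O)C1(C)C`: 1.4 ug/mL
- compound 2 `COC1=C(C)C(=O)/C(=C(O)/C=C/c2c(C)cccc2C)C(=O)C1(C)C`: 8.3 ug/mL
- compound 3 `COC1=C(C)C(=O)/C(=C(O)/C=C/c2ccco2)C(=O)C1(C)C`: 10 ug/mL

Compound 3 and compound 2 sit together at the high end of these numbers, since the step between them is a 1.2-fold higher number from compound 2 to compound 3 (0.08 log units; within the scatter). Compound 1 stands apart from both, with a 5.9-fold higher number from compound 1 to compound 2 (0.77 log units; beyond the scatter) and a 7.1-fold higher number from compound 1 to compound 3 (0.85 log units; beyond the scatter).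

The next compound, compound 4 `COC1=C(C)C(=O)/C(=C(O)/C=C/c2nccs2)C(=O)C1(C)C`, carries 1,3-thiazol-2-yl in place of furan-2-yl on a double-bonded chain carbon bound to a double-bonded chain carbon. Among the compounds with values here, no measured step makes this exact swap of one five-membered aromatic ring for another. The two large steps both leave the 4-bromophenyl of compound 1, which is not involved here. The closer guide is the swap of 2,6-dimethylphenyl for furan-2-yl, a clear change of ring that still gave only a 1.2-fold higher number from compound 2 to compound 3 (0.08 log units; within the scatter). Three compounds are thin evidence, but no shift beyond the scatter is expected.

In this assay the expected step is a 1.1-fold lower number from compound 3 to compound 4 (0.05 log units; within the scatter). The estimate for compound 4 is 9 ug/mL, with an expected range from 3.5 ug/mL to 25 ug/mL.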

Compound 4, concentration for half-maximal effect: 3.5 ug/mL
Compound 4: the middle estimate sits 2.6-fold (0.41 log units) above what was measured; measured number inside the range.
By their numbers in this assay, from the lowest: compound 1; then compound 4; then compounds 2 and 3 (each within the scatter of the next).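

In this assay, the place on a double-bonded chain carbon bound to a double-bonded chain carbon proves sensitive even to a swap between two five-membered aromatic rings: 1,3-thiazol-2-yl in place of furan-2-yl gives a 2.9-fold lower number from compound 3 to compound 4 (0.46 log units; beyond the scatter) in this series. The earlier change from 2,6-dimethylphenyl to furan-2-yl stayed within the scatter, so a change of ring alone does not predict the size of a step, while the new ring gives a 2.4-fold lower number from compound 2 to compound 4 (0.38 log units; beyond the scatter) and leaves compound 4 in the middle, with a 2.5-fold higher number from compound 1 to compound 4 (0.40 log units; beyond the scatter) showing that the 4-bromophenyl group of compound 1 still gives the lowest number. No measurement at hand explains this shift.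

Whether the ring nitrogen, the ring sulfur or both together account for the step remains open. Also open, as far as these compounds go, is how a pyridin-2-yl ring or a 4-aminophenyl group would compare at this place.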